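The compounds below may be only part of what the source reports. "The series", "measured", "known", "first", "only" and "open" are said of these compounds alone.

Compound 1, `O=C(NS(=O)(=O)c1ccc(F)cc1)c1ccc(Nc2nc(NC3(c4ccc(Cl)cc4)CC3)nc(OCC(F)(F)F)n2)cc1`, gives 193 nm/s in a physicochemical assay for permeability, using PAMPA, at pH 7.4; a higher number here means that the compound crosses the layer faster, a lower number that the compound crosses the layer more slowly.
Compound 2, `CCS(=O)(=O)NC(=O)c1ccc(Nc2nc(NC3(c4ccc(Cl)cc4)CC3)nc(OCC(F)(F)F)n2)cc1`, gives 28 nm/s in this assay.

Compound 2 stands lowest of the two numbers in this assay; its nearest neighbour is compound 1, which lies above it by the step of a 6.9-fold lower number from compound 1 to compound 2 (0.84 log units; beyond the scatter). Compound 3, `CS(=O)(=O)NC(=O)c1ccc(Nc2nc(NC3(c4ccc(Cl)cc4)CC3)nc(OCC(F)(F)F)n2)cc1`, is not yet measured. Relative to compound 2 it carries hydrogen in place of methyl on a saturated chain carbon bound to a sulfonyl sulfur.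

For the measured compounds named here, only one measured step exists, a 6.9-fold lower number from compound 1 to compound 2 (0.84 log units; beyond the scatter), and it concerns exchanging a 4-fluorophenyl for an ethyl on the sulfonyl sulfur, a far larger alteration than the one from compound 2 to compound 3. That step therefore bears on the present one only loosely, and the removal of a single carbon from the ethyl gives little ground for a movement beyond the scatter. The step of a 1.3-fold lower number from compound 2 to compound 3 (0.10 log units; within the scatter) is expected to be small, if anything slightly downward. Compound 3 is estimated at 22 nm/s, with a range from 9 nm/s to 50 nm/s.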

Compound 3, apparent permeability: 11 nm/s
The estimate for compound 3 lay 2.0-fold (0.30 log units) above the measured number; low and high end bracket the measured number.
By their numbers in this assay, from the lowest: compound 3; then compound 2; then compound 1.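

In this assay, removing the single carbon from the ethyl on the sulfonyl sulfur gives a 2.5-fold lower number from compound 2 to compound 3 (0.41 log units; beyond the scatter), so even a change of this size registers at this position. Set against the 4-fluorophenyl, the methyl gives an 18-fold lower number from compound 1 to compound 3 (1.24 log units; beyond the scatter), and the three groups on the sulfonyl sulfur now rank methyl, ethyl, 4-fluorophenyl from the lowest number upward, with no compound shown going against that order. Nothing shown offers a measured reason for these steps.

On these data alone, it remains open whether a longer chain such as propyl would continue the rise seen from methyl to ethyl, or whether a branched group such as isopropyl would behave the same way. Also open, as far as these compounds go, is how an unsubstituted phenyl or a dimethylamino group on the sulfonyl sulfur would compare with the 4-fluorophenyl.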